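This account rests on a few compounds, and the source may have more. Where it says the series, first, only, none or still open, it means among the compounds named here.

Measured compounds:
- Compound 1, `O=C1NC(=S)/C(=C/c2cccc(Cl)c2)S1`, gives 5.44% in a functional assay on HEp-2 cells (Homo sapiens) for cytotoxicity, read by MTT assay, with a stated time of 72 h, tested at 2.5 ug/mL; on this read-out lower numbers stand for less inhibition of growth and higher numbers for more inhibition of growth at the one concentration tested.
- Compound 2, `O=C1NC(=S)/C(=C/c2ccc(Cl)c(Cl)c2)S1`, gives 5.03% in this assay.

Among these two numbers compound 1 stands highest, yet its nearest neighbour is compound 2, and the single step of a number 0.4 percentage points lower from compound 1 to compound 2 (within the scatter) is within the scatter, so the two compounds cannot be told apart by this read-out. Both values sit low on a scale where the top would mean complete inhibition of growth, so neither compound does much to the cells at the one concentration tested.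

Compound 3, `O=C1NC(=S)/C(=C/c2cccc(Br)c2)S1`, has not yet been measured. It differs from compound 1 by bromo in place of chloro on an aromatic carbon. Among the compounds with values here, no measured step changes this halogen; the only step known, from compound 1 to compound 2, adds a second chloro and moves the number by a number 0.4 percentage points lower from compound 1 to compound 2 (within the scatter), which is no change beyond the scatter. Swapping one halogen for another at the same place is therefore expected to leave this assay essentially where it is, with no step beyond the scatter. The step from compound 1 to compound 3 is estimated at a number 0.6 percentage points higher from compound 1 to compound 3 (within the scatter). Compound 3 is estimated to give 6%, in a range from 0% to 18%.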

Compound 3, percent growth inhibition at one concentration: -1.82%
Compound 3: the middle estimate sits 7.8 percentage points above what was measured; measured number below the stated range.
By their numbers in this assay, from the lowest: compounds 3, 2 and 1 (each within the scatter of the next).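

The halogen at this place on the aromatic ring had not been changed before, and in this assay bromo in place of chloro gives a number 7.3 percentage points lower from compound 1 to compound 3 (within the scatter), so compound 1 and compound 3 cannot be told apart by this read-out. This adds to the earlier step, which added a second chloro and left the halogen at this place untouched: exchanging one halogen for the other at this place also produces no change that can be read, and compound 3, at -1.82%, shows no sign of inhibiting growth at the one concentration tested. Nothing at hand explains these numbers or says what the two halogens do here.

As far as these compounds go, whether a group of a different kind at this place, such as an amine or a carboxylic acid, would move the number clearly beyond the scatter remains open. Also open, from the compounds shown here alone, is whether these compounds would differ from one another at another concentration, since a single concentration says nothing about how growth inhibition would follow the dose.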